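A Shorter Chain: From Compound 2 to Compound 3

This account rests on a few compounds, and the source may have more. Where it says the series, first, only, none or still open, it means among the compounds named here.

For the measured compounds named here, compound 2 `CCCOC(=O)Nc1ccc([Se]C#N)cc1` gives 9300 nM in a functional assay on CCRF-CEM cells (Homo sapiens) for cytotoxicity, read by MTT assay, with a stated time of 72 h (a lower number here means a stronger inhibitor of growth, a higher number a weaker inhibitor of growth), the lower of the two numbers measured so far; compound 1 `N#C[Se]c1ccc(NC(=O)Oc2ccc(F)cc2)cc1` gives 12600 nM in this assay, and the two values lie within the scatter of each other, so neither can be called the stronger. Compound 3 `CCOC(=O)Nc1ccc([Se]C#N)cc1` differs from compound 2 by one change: hydrogen in place of methyl on a saturated chain carbon, two bonds along the chain from an oxygen next to a carbonyl group, that is, propyl to ethyl. Going by the values given here, no measured pair shows what such a change does here, so the expected step is essentially nothing beyond the scatter, estimated as a 1.1-fold higher number from compound 2 to compound 3 (0.03 log units; within the scatter). Compound 3 is therefore expected to give about 10000 nM, somewhere between 4000 nM and 25000 nM.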

Compound 3, concentration for 50% growth inhibition: 9800 nM
Estimate against measurement, compound 3: 1.0-fold (0.01 log units) above, within the range that was stated.
By their numbers in this assay, from the lowest: compounds 2, 3 and 1 (each within the scatter of the next).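

For the compounds shown here, this is the first measured pair at this position. In this assay the change from propyl to ethyl gives a 1.1-fold higher number from compound 2 to compound 3 (0.02 log units; within the scatter) and so the two compounds cannot be told apart, which means that at this chain length the end methyl can go without a measurable difference in this read-out. Nothing measured here offers an explanation for this result. Still open, going by these compounds, is whether a shorter methoxy group, a longer chain such as butoxy, or an amine at the chain end would give a number beyond the scatter.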